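Methoxy for methyl on a phenethylthio side chain

This account rests on a few compounds, and the source may have more. Where it says the series, first, only, none or still open, it means among the compounds named here.

Compound 1 `C#CCNC1CCc2c(SCc3cccc(F)c3)cccc21` gives 11600 nM in an ADME assay on isolated protein for inhibition of Amine oxidase [flavin-containing] B (Homo sapiens); a higher number here means a weaker inhibitor, a lower number a stronger inhibitor. Compound 2 `C#CCNC1CCc2c(SCc3ccc(Br)cc3)cccc21` gives 488 nM in this assay. Compound 3 `C#CCNC1CCc2c(SCCc3ccc(C)cc3)cccc21` gives 4520 nM in this assay.

Among the three measured compounds, compound 3 stands second highest: its number lies below that of compound 1 and well above that of compound 2, the only compound whose number is low. Going by the values given here, the one change measured as a step, the move from 3-fluorophenyl to 4-bromophenyl on a saturated chain carbon bound to a sulfur, is large: a 24-fold lower number from compound 1 to compound 2 (1.38 log units; beyond the scatter). That step, however, concerns the benzyl-type side chain, not the two-carbon chain of compound 3, and it swaps a halogen and its position rather than a para substituent of one size for another.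

Compound 4 `C#CCNC1CCc2c(SCCc3ccc(OC)cc3)cccc21` differs from compound 3 only in this: methoxy in place of methyl on an aromatic carbon. Among the compounds with values here, no measured step bears directly on this exchange. A change this small, far out on the side chain, is expected to move the number little, and if at all, slightly upward, so the expected step is a 1.3-fold higher number from compound 3 to compound 4 (0.12 log units; within the scatter). Compound 4 is therefore estimated at 6000 nM in this assay, with a range from 2000 nM to 18000 nM.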

Compound 4, half-maximal inhibitory concentration: 4590 nM
Compound 4: the middle estimate sits 1.3-fold (0.12 log units) above what was measured; the range from low to high includes it.
By their numbers in this assay, from the lowest: compound 2; then compounds 3 and 4 (each within the scatter of the next); then compound 1.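

In this assay methoxy in place of methyl on the aromatic carbon gives a 1.0-fold higher number from compound 3 to compound 4 (0.01 log units; within the scatter) and so leaves the two compounds indistinguishable. Going by these compounds alone, the earlier compounds offered no step at this position; this pair is the first to show that, on the phenethylthio side chain, 4-methylphenyl and 4-methoxyphenyl read alike, even though methoxy brings an oxygen and a hydrogen-bond acceptor that methyl lacks. Nothing measured alongside these values accounts for this sameness, and the pair on its own offers no explanation for it.

The compounds shown leave open whether this tolerance extends to other groups on the same aromatic carbon, such as a hydroxyl, a dimethylamino group or a bromine, the atom carried by the 4-bromophenyl of compound 2 on its own side chain. They also leave open how 4-methylphenyl and 4-methoxyphenyl would compare on a longer chain between the sulfur and the aromatic ring, since this single pair speaks only for the two-carbon chain of compound 3 and compound 4.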